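The source may report more compounds than this note shows. Statements on the series, on what has been measured and on what is new or still open speak of the compounds shown alone.

Measured so far:
compound 1, `CN(C)c1c(C#N)c2c(N)ncnc2n1C`, 3760 nM
compound 2, `C[C@@H]1CCCN1c1c(C#N)c2c(N)nc(Nc3cn(C)nc3Cl)nc2n1C`, 21 nM
compound 3, `Cn1c(NCc2ccccc2F)c(C#N)c2c(N)ncnc21`, 1740 nM

In an assay on isolated protein for inhibition of Leucine-rich repeat serine/threonine-protein kinase 2 variant G2019S (Homo sapiens), read by TR-FRET and LanthaScreen, with stated times of 50 min and 30 min, in the presence of a further agent that is not named here (a higher number here means a weaker inhibitor, a lower number a stronger inhibitor), compound 2 gives the lowest of the three numbers. Its nearest neighbour on that scale is compound 3, and the gap between them lies beyond the usual scatter; compound 1 stands further off still. Compound 2 is therefore the strongest inhibitor among the three compounds measured here.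

Compound 4, `Cc1n[nH]cc1Nc1nc(N)c2c(C#N)c(N3CCC[C@H]3C)n(C)c2n1`, keeps the shared core of compound 2 and changes only the group on a nitrogen on an aromatic ring: 3-methyl-1H-pyrazol-4-yl in place of 3-chloro-1-methyl-1H-pyrazol-4-yl on a nitrogen on an aromatic ring. The chlorine and the methyl on the ring nitrogen are lost, and a ring nitrogen that carries a hydrogen comes in. Among the compounds with values here, no step between two measured compounds covers this kind of exchange, so there is nothing to lean on except the place where the change sits.

The step from compound 2 to compound 4 is expected to be small, with a mild loss of potency at most, and the estimate is a 1.7-fold higher number from compound 2 to compound 4 (0.22 log units; within the scatter). Compound 4 is therefore estimated at 35 nM, with a range from 10 nM to 120 nM.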

Compound 4, half-maximal inhibitory concentration: 27 nM
For compound 4 the middle estimate is 1.3-fold (0.11 log units) above the measured one; low and high end bracket the measured number.
By their numbers in this assay, from the lowest: compounds 2 and 4 (each within the scatter of the next); then compound 3; then compound 1.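

In this assay, within the data shown here, 3-methyl-1H-pyrazol-4-yl in place of 3-chloro-1-methyl-1H-pyrazol-4-yl on a nitrogen on an aromatic ring gives a 1.3-fold higher number from compound 2 to compound 4 (0.11 log units; within the scatter), the only step so far that can be read at this place. It shows that the chlorine and the methyl on the ring nitrogen can both go, and a ring nitrogen carrying a hydrogen can come in, with the two numbers staying within the scatter of each other. No measurement shown here accounts for this result.

The exchange alters these features together, so compounds 2 and 4 do not separate the part played by the chlorine from that of the methyl on the ring nitrogen. From the compounds shown here alone, whether an ethyl or a 2-hydroxyethyl chain on that ring nitrogen, or a bromine in place of the chlorine, would read alike stays open.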